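A silicon-bearing group on a weak compound

The source may report more compounds than this note shows. Statements on the series, on what has been measured and on what is new or still open speak of the compounds shown alone.

Among the compounds with values here, compound 2 (`COc1cc(C2=C(c3cc(C)c(OC)c(C)c3)C(O)CC2=O)cc(OC)c1OC`) stands at the weak end of the values measured so far. In an ADME assay on L132 cells (Homo sapiens) for cytotoxicity, read by MTT assay, with a stated time of 72 h (on this read-out higher numbers stand for weaker inhibition and lower numbers for stronger inhibition), compound 2 gives > 100 ug/mL as a limit of the assay and not a number. Compound 1 (`COc1ccc(C2=C(c3cc(OC)c(OC)c(OC)c3)C(=O)C(O)C2)cc1`) gives < 1 ug/mL as a limit as well. Compound 3 (`COc1ccc(C2=C(c3cc(OC)c(OC)c(OC)c3)C(=O)C(O)C2)cc1F`) likewise gives < 1 ug/mL as a limit.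

Compound 4 (`COc1cc(C2=C(c3cc(C)c(OC)c(C)c3)C(O[SiH2]C(C)(C)C)CC2=O)cc(OC)c1OC`) has not been measured yet. Its difference from compound 2 is a group of 5 heavy atoms (4 carbon, 1 silicon; no ring) in place of a hydrogen atom, on an oxygen on a saturated carbon and the rest of the structure stays the same.

Within the data shown here, only one measured step bears on this at all. That step that the two limits leave unreadable from compound 1 to compound 3 puts fluoro in place of hydrogen on an aromatic carbon, so it has no readable size and concerns another kind of change. With so little to go on, the expectation is that this assay shows no change beyond the usual scatter, in either direction. The expected step of a number no higher from compound 2 to compound 4 (the limit leaves the size open) is therefore small and uncertain. Compound 4 is estimated at 100 ug/mL with an expected range of 20 ug/mL to 300 ug/mL, and a limit rather than a number is also expected.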

Compound 4, half-maximal inhibitory concentration: > 100 ug/mL
Compound 4 gave a limit, no number; the forecaster's own chance of this, stated with the estimate: 55%; the middle value sits exactly at the limit.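

In this assay compound 4 gives > 100 ug/mL, a limit and not a number. Within the data shown here, compound 2 stands at the same limit, and no step between compound 2 and compound 4 can be read. The compounds shown leave open how far past that limit either compound lies.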